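This account rests on a few compounds, and the source may have more. Where it says the series, first, only, none or still open, it means among the compounds named here.

Measured in an ADME assay on U2OS cells (Homo sapiens) for cytotoxicity; a lower number here means that less compound is tolerated, a higher number that more compound is tolerated:
- compound 1 `CC(C)(O)c1cc2c(-c3ccc4ccccc4c3)nccc2[nH]1`: 22500 nM
- compound 2 `CC(C)(O)c1cc2c(-c3ccc(C(F)(F)F)cc3)nccc2[nH]1`: 72300 nM

Compound 2 carries the higher number of the two, and its gap to compound 1 lies beyond the usual scatter. The next compound to be read is compound 3 `Cc1ccc(-c2nccc3[nH]c(C(C)(C)O)cc23)cc1`, which puts methyl in place of trifluoromethyl on an aromatic carbon, para to a large group: methyl in place of trifluoromethyl on an aromatic carbon.

Among the measured compounds shown here, no measured pair isolates this change, so the expectation rests on judgement and on only two values. With compound 2 at 72300 nM as the starting point, no step beyond the scatter is expected, with at most a slight drift to a lower number. The estimated move is a 1.2-fold lower number from compound 2 to compound 3 (0.08 log units; within the scatter). For compound 3 the expected value is 60000 nM, with an estimated range of 25000 nM to 130000 nM.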

Compound 3, half-maximal cytotoxic concentration: 38500 nM
Estimate against measurement, compound 3: 1.6-fold (0.19 log units) above; the range from low to high includes it.
By their numbers in this assay, from the lowest: compounds 1, 3 and 2 (each within the scatter of the next, the first and the last beyond it).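

In this assay, among the compounds shown here, methyl in place of trifluoromethyl on an aromatic carbon, para to a large group, gives a 1.9-fold lower number from compound 2 to compound 3 (0.27 log units; within the scatter) and is the first single-place step. At this position, then, the exchange of trifluoromethyl for methyl leaves the read-out within the usual scatter, even though the group drops from four heavy atoms to one. No supporting data bear on why this step is as small as it is.

Still open, going by these compounds, is whether a group of another kind at this position, such as an amine, a carboxylic acid or a nitrile, would also stay within the scatter of compound 2. The compounds shown also leave open whether methyl in place of trifluoromethyl would give a similar step on another aromatic carbon.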